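Trading a hydroxycarbamoyl arm for a carboxybutyl group

The compounds below may be only part of what the source reports. "The series", "measured", "known", "first", "only" and "open" are said of these compounds alone.

Compound 1 `O=C(O)c1ccc(OCCOc2ccc3cc2COC/C=C/COCc2cccc(c2)-c2ccnc(n2)N3)cc1`: 29700 nM
Compound 2 `O=C(NO)c1cccc(NCCOc2ccc3cc2COC/C=C/COCc2cccc(c2)-c2ccnc(n2)N3)c1`: 2010 nM
Compound 3 `O=C(O)CCCCCCC(=O)Nc1ccc(NCCOc2ccc3cc2COC/C=C/COCc2cccc(c2)-c2ccnc(n2)N3)cc1`: 2700 nM

These three compounds share one core and differ in a single arm. All were tested in a functional assay on HCT-116 cells (Homo sapiens) for antiproliferative activity, read by MTT assay, with a stated time of 72 h; a lower number here means a stronger inhibitor, a higher number a weaker inhibitor. Compound 2 and compound 3 stand level within the usual scatter, at the low end of the three numbers, while compound 1 lies far higher.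

The next compound, compound 4 `O=C(O)CCCCCCOc1ccc2cc1COC/C=C/COCc1cccc(c1)-c1ccnc(n1)N2`, keeps the core but gives up the aromatic arm of compound 2: 4-carboxybutyl in place of (3-(hydroxycarbamoyl)phenyl)amino on a saturated chain carbon, two bonds along the chain from an oxygen on an aromatic ring. In words, 4-carboxybutyl takes the place of (3-(hydroxycarbamoyl)phenyl)amino on a saturated chain carbon, two bonds along the chain from an oxygen on an aromatic ring.

Within the data shown here, one measured step bears directly on this change: a 15-fold lower number from compound 1 to compound 2 (1.17 log units; beyond the scatter). That step is large and leaves the same arm in view. Compound 4 ends in a carboxy group, as does compound 1 with 29700 nM, so a clear rise is expected. Compound 3 also ends in a carboxy group yet gives 2700 nM, so the rise may fall short of the full reversal. The expected change is a 6.0-fold higher number from compound 2 to compound 4 (0.78 log units; beyond the scatter), beyond the scatter. Compound 4 is estimated in this assay at 12000 nM, with an expected range from 3000 nM to 40000 nM.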

Compound 4, half-maximal inhibitory concentration: 6060 nM
For compound 4 the middle estimate is 2.0-fold (0.30 log units) above the measured one; the range from low to high includes it.
By their numbers in this assay, from the lowest: compounds 2 and 3 (each within the scatter of the next); then compound 4; then compound 1.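

This result shows that an arm ending in a carboxy group need not sit at the high end in this assay: with the ringless 4-carboxybutyl in place of 4-carboxyphenoxy at this saturated chain carbon, the read-out shows a 4.9-fold lower number from compound 1 to compound 4 (0.69 log units; beyond the scatter), so the carboxy ending alone does not set the number among these compounds. The (3-(hydroxycarbamoyl)phenyl)amino arm still gives the better result of the pair, since replacing it with 4-carboxybutyl produces a 3.0-fold higher number from compound 2 to compound 4 (0.48 log units; beyond the scatter), a modest step that is nevertheless beyond the scatter and smaller than the earlier 15-fold lower number from compound 1 to compound 2 (1.17 log units; beyond the scatter). No measurement available here explains either step.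

That swap removes the benzene ring, the amino link and the hydroxycarbamoyl group in one move, so the compounds shown cannot tell which of these parts accounts for the difference. A butyl chain ending in a hydroxycarbamoyl group would separate the end group from the ring, while a longer chain ending in a carboxylic acid would test whether chain length matters at this position.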